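This account rests on a few compounds, and the source may have more. Where it says the series, first, only, none or still open, it means among the compounds named here.

Of the compounds shown here, three built on one shared core have been tested in a functional assay on A549 cells (Homo sapiens) for antiproliferative activity, read by MTT assay, with a stated time of 72 h; on this read-out lower numbers stand for stronger inhibition and higher numbers for weaker inhibition. Compound 1 `COc1cc(-n2ncnc2-c2cccc([N+](=O)[O-])c2)cc(OC)c1OC` gives only a limit there, > 10000 nM. Compound 2 `COc1cc(-n2ncnc2-c2ccccc2)cc(OC)c1OC` likewise gives only a limit, > 10000 nM. Compound 3 `CCOc1cccc(-c2ncnn2-c2cc(OC)c(OC)c(OC)c2)c1` also gives only a limit, > 10000 nM. The steps between them, a step that the two limits leave unreadable from compound 1 to compound 2, a step that the two limits leave unreadable from compound 1 to compound 3 and a step that the two limits leave unreadable from compound 2 to compound 3, cannot be sized because of the limit of > 10000 nM in this assay, at which 3 of the 3 values shown sit. Compound 4 `COc1cc(-n2ncnc2-c2ccc(SC)cc2)cc(OC)c1OC` is the next to be measured; it differs from compound 2 by methylsulfanyl in place of hydrogen on an aromatic carbon. Among the compounds with values here, no measured step covers such a change, so neither direction nor size can be read from them, and the expectation rests only on compound 2 sitting at its limit. Compound 4 is therefore expected at 10000 nM, within 3000 nM to 30000 nM. This corresponds to an expected a number no higher from compound 2 to compound 4 (the limit leaves the size open).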

Compound 4, half-maximal inhibitory concentration: 800 nM
Compound 4: middle estimate off by 13-fold (1.10 log units), on the high side, and the stated range ends above it.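

In this assay, within the data shown here, methylsulfanyl in place of hydrogen gives an at least 12-fold lower number from compound 2 to compound 4 (1.09 log units; beyond the scatter), the first step in this set that can be read. Compound 2 gives only a limit, > 10000 nM, so this size is a minimum. The change shows that a substituent on this aromatic carbon, para to a large group, can bring the number down from that limit into a measurable range.

The compounds shown leave open whether an amine here would give a similar number, and whether a longer chain on the sulfur would keep it.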